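The source may hold more compounds than are shown below. What is called first, only, known or untested is meant among the compounds shown, and "the series" means these compounds.

Two compounds of the series have been run in a physicochemical assay for solubility, using the shake flask method, in phosphate buffer, measured as kinetic solubility, with a stated time of 20 h, at pH 6.5; on this read-out lower numbers stand for lower solubility and higher numbers for higher solubility. Compound 1 `FC(F)(F)c1cccc(-c2nc3cnc(Nc4ccncn4)cc3[nH]2)c1` gives < 5000 nM, which is a limit of the assay rather than a number. Compound 2 `Fc1ccc(-c2nc3cnc(Nc4cc(C(F)(F)F)ccn4)cc3[nH]2)cc1F` gives < 5000 nM, again a limit of the assay and not a number. For the measured compounds named here, compound 2 thus stands where the only other measured compound stands: the limit of < 5000 nM in this assay, at which 2 of the 2 values shown sit. Going by the values given here, no two measured compounds differ in a single place, so no measured step is available on the shared core, and the two limits allow no ordering of compound 1 and compound 2.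

Compound 3 `Fc1ccnc(Nc2cc3[nH]c(-c4ccc(F)c(F)c4)nc3cn2)c1` has not been measured in this assay. It differs from compound 2 by fluoro in place of trifluoromethyl on an aromatic carbon, a fluoro in place of trifluoromethyl on an aromatic carbon. With both measured values sitting at the limit, the step from compound 2 to compound 3 is expected to be a step that the limit leaves unreadable from compound 2 to compound 3, not clearly beyond the scatter. Compound 3 is expected to give 4000 nM in this assay, within 1000 nM to 16000 nM, with a fair chance that only a limit is reported.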

Compound 3, solubility: < 5000 nM
Compound 3: no number, only a limit; the forecaster's own chance of this, stated with the estimate: 55%; the middle value is on the limit's open side.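

No step can be read from compound 2 to compound 3 in this assay, because both results are limits of the assay and not numbers: the limit of < 5000 nM in this assay, at which 3 of the 3 values shown sit.

The compounds shown leave open any ordering of compound 1, compound 2 and compound 3 in this assay.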